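This account rests on a few compounds, and the source may have more. Where it says the series, first, only, none or still open, it means among the compounds named here.

In a functional assay on Jurkat cells (Homo sapiens) (a lower number here means a stronger inhibitor, a higher number a weaker inhibitor), compound 1 `CC(C)[C@H](NC(=O)COc1cccc2ccccc12)C(=O)N[C@@H](CC(=O)O)C(=O)COc1ccccc1` gives 14000 nM. Compound 2 `CC(C)[C@H](NC(=O)COc1cccc2ccccc12)C(=O)N[C@@H](CC(=O)O)C(=O)COc1ccc2ccccc2c1` reads > 100000 nM, which is a limit of the assay and not a number. Compound 3 `CC(C)[C@H](NC(=O)COc1cccc2ccccc12)C(=O)N[C@@H](CC(=O)O)C(=O)COc1cc(C(F)(F)F)cc(C(F)(F)F)c1` reads > 100000 nM, also a limit. Compound 2 therefore stands at the limit of > 100000 nM in this assay, at which 2 of the 3 values shown sit, with no exact value to start from.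

Compound 4 `CC(C)[C@H](NC(=O)COc1cccc2ccccc12)C(=O)N[C@@H](CC(=O)O)C(=O)COc1ccc(C(N)=O)cc1` has 4-carbamoylphenyl in place of naphthalen-2-yl on an oxygen on a saturated carbon. Among the compounds with values here, the one measured step at this place is an at least 7.1-fold higher number from compound 1 to compound 2 (0.85 log units; beyond the scatter), and compound 4 goes back to a single aromatic ring, as in compound 1. A step of similar size towards a lower number is therefore expected, though compound 3 warns that an added group on the phenyl may not allow this. The expected step is an at least 3.3-fold lower number from compound 2 to compound 4 (0.52 log units; beyond the scatter). For compound 4 the estimate is 30000 nM, with an expected range of 7000 nM to 100000 nM.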

Compound 4, half-maximal inhibitory concentration: > 100000 nM
Compound 4 was reported as a limit; the forecaster's own chance of this, stated with the estimate: 35%; middle value at least 3.3-fold (0.52 log units) from the limit.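

Carbamoyl in place of hydrogen on the phenyl gives an at least 7.1-fold higher number from compound 1 to compound 4 (0.85 log units; beyond the scatter), so returning to a single aromatic ring does not by itself restore a measurable value. The result for compound 4 is a limit of the assay and not a number, and the step from compound 2 cannot be read because both values are limits. Among these compounds, only compound 1, with its plain phenyl, gives an exact value: the limit of > 100000 nM in this assay, at which 3 of the 4 values shown sit.

The compounds shown leave open whether a single fluorine or methyl on the phenyl would retain a measurable value. They also leave open how an amine or a carboxylic acid on that ring would read.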